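This account rests on a few compounds, and the source may have more. Where it says the series, first, only, none or still open, it means among the compounds named here.

Values in a functional assay on HT-29 cells (Homo sapiens) for cytotoxicity, read by MTT assay, with a stated time of 2 days; on this read-out higher numbers stand for weaker inhibition and lower numbers for stronger inhibition:
- compound 1 `CC(=O)OC[C@H]1O[C@H](O[C@]2(COC(C)=O)O[C@H](CO)[C@@H](O)[C@@H]2OC(=O)/C=C/c2ccc(O)cc2)[C@H](O)[C@@H](OC(C)=O)[C@@H]1O` gives 2100 nM
- compound 2 `CC(=O)OC[C@H]1O[C@H](O[C@]2(COC(C)=O)O[C@H](CO)[C@@H](O)[C@@H]2OC(=O)/C=C/c2ccc(O)cc2)[C@H](OC(C)=O)[C@@H](O)[C@@H]1O` gives 3960 nM

Only these two numbers are available so far. Compound 2 at 3960 nM lies within the usual scatter of compound 1 at 2100 nM, so the two cannot be told apart in this assay.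

Compound 3 `CC(=O)OC[C@H]1O[C@H](O[C@]2(COC(C)=O)O[C@H](CO)[C@@H](O)[C@@H]2OC(=O)/C=C/c2ccc(O)c(O)c2)[C@H](OC(C)=O)[C@@H](O)[C@@H]1O` departs from compound 2 by hydroxy in place of hydrogen on an aromatic carbon. This places hydroxy in place of hydrogen on an aromatic carbon, turning 4-hydroxyphenyl into 3,4-dihydroxyphenyl. For the measured compounds named here, no measured pair carries this change, so the only guide is the level of compound 2 at 3960 nM. A slight shift towards stronger inhibition is expected, but nothing beyond the scatter in this assay. The expected change is a 1.4-fold lower number from compound 2 to compound 3 (0.15 log units; within the scatter). For compound 3 the estimated value is 2800 nM, with an expected range of 1000 nM to 8000 nM.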

Compound 3, half-maximal inhibitory concentration: 460 nM
Beside the measured number, compound 3's estimate is 6.1-fold (0.78 log units) above it; the whole stated range lies above it.
By their numbers in this assay, from the lowest: compound 3; then compounds 1 and 2 (each within the scatter of the next).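

In this assay, hydroxy in place of hydrogen on an aromatic carbon, ortho to a hydroxy group and meta to a large group, gives an 8.6-fold lower number from compound 2 to compound 3 (0.93 log units; beyond the scatter). For the compounds shown here, this is the first step that can be read beyond the scatter, and it shows that this place on the aromatic ring, unsubstituted in compounds 1 and 2, responds to a change, with 3,4-dihydroxyphenyl giving the lower number than 4-hydroxyphenyl on the core of compound 2. Nothing at hand accounts for the size of this step.

As far as these compounds go, whether a methoxy group, a fluorine atom or an amine at the same place would give a comparable step remains open. Also open, from the compounds shown here alone, is whether 3,4-dihydroxyphenyl gives a step of this size on the core of compound 1.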